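Thiophene for Pyridine at the Core of Compound 1

A few compounds are considered here, and "the series" means these few. Any claim that something is new, unique, unknown or untested is made for them only; others in the source may bear on it.

Compound 1: `Oc1ccc(-c2cc(-c3cccnc3)nc(-c3ccccc3Cl)c2)cc1`, result in cytotoxicity: "not determined" (no result reported)
Compound 2: `Oc1cccc(-c2cc(-c3ccccn3)nc(-c3ccccc3Cl)c2)c1`, result in cytotoxicity: "not determined" (no result reported)
Compound 3: `Oc1cccc(-c2cc(-c3cccc(Cl)c3)nc(-c3ccco3)c2)c1`, result in cytotoxicity: 2460 nM

The three measured compounds share a core carrying three aryl groups. In a functional assay on HCT-15 cells (Homo sapiens) for cytotoxicity, read by CCK-8 assay and cell counting, with a stated time of 2 days (on this read-out lower numbers stand for stronger inhibition and higher numbers for weaker inhibition), only compound 3 gives a number, 2460 nM. Compound 1 has no result in this assay, and the same holds for compound 2, so compound 1 stands on no number at all, and nothing among the reported data allows one compound to be ordered against another.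

Compound 4, `Oc1ccc(-c2cc(-c3ccsc3)nc(-c3ccccc3Cl)c2)cc1`, differs from compound 1 in one place: thiophen-3-yl in place of pyridin-3-yl on an aromatic carbon. Among the compounds with values here, with no value for compound 1 and no step between measured compounds recorded, there is no measured step from which the size of this change in this assay could be read. Within the data shown here, the only anchor is compound 3, whose half-maximal inhibitory concentration in this assay is 2460 nM; compound 4 carries a different set of aryl groups, so this anchor is loose.

On that basis, compound 4 is expected to fall near compound 3, with an estimated value in this assay of 3000 nM, in a range from 600 nM to 15000 nM.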

Compound 4, half-maximal inhibitory concentration: 5830 nM
Compound 4: middle estimate off by 1.9-fold (0.29 log units), on the low side, within the range that was stated.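

Within the data shown here, with compound 4 at 5830 nM in this assay and compound 1 without a single number there, no step between compound 1 and compound 4 can be read. Nothing shown bears on the reason for this result. The compounds shown leave open what thiophen-3-yl in place of pyridin-3-yl does to cytotoxicity in these cells.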